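A few compounds are considered here, and "the series" means these few. Any claim that something is new, unique, unknown or untested is made for them only; others in the source may bear on it.

Among the compounds with values here, compound 2 `COc1ccc(OCCCCCN2CCCC(COC(=O)c3ccccc3N3C(=O)CC(C)C3=O)C2)cc1OC` stands highest of the two numbers measured so far in an in vitro functional assay on HEK ts201 cells for antagonist activity at Neuronal acetylcholine receptor; alpha3/beta4 (Homo sapiens), read by fluorescence and calcium flux; a higher number here means a weaker inhibitor, a lower number a stronger inhibitor: in this assay compound 2 gives 2000000 nM. Its nearest neighbour, compound 1 `[N-]=[N+]=NCCCN1CCCC(COC(=O)c2ccccc2-c2ccccc2)C1`, gives 1820 nM in this assay, a gap far beyond the usual scatter, so compound 2 is clearly the weaker inhibitor of the two. The next compound, compound 3 `CC1CC(=O)N(c2ccccc2C(=O)OCC2CCCN(CCCCCc3ccccc3)C2)C1=O`, differs from compound 2 in one place: phenyl in place of 3,4-dimethoxyphenoxy on a saturated chain carbon, five bonds along the chain from an amine nitrogen in a ring. Within the data shown here, no pair of measured compounds tracks this kind of change, so the size of the step is open. Because compound 2 gives 2000000 nM the number has little room to rise, and a modest fall is expected, while the rest of the molecule is kept from compound 2, so no large gain is expected either. For compound 3 the estimated value in this assay is 300000 nM, within a range from 30000 nM to 2000000 nM. The expected step is a 6.7-fold lower number from compound 2 to compound 3 (0.82 log units; beyond the scatter).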

Compound 3, half-maximal inhibitory concentration: 4170 nM
For compound 3 the middle estimate is 72-fold (1.86 log units) above the measured one; measured number outside the range, below it.
By their numbers in this assay, from the lowest: compound 1; then compound 3; then compound 2.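

Swapping 3,4-dimethoxyphenoxy for phenyl, on a saturated chain carbon five bonds along the chain from an amine nitrogen in a ring, gives a 480-fold lower number from compound 2 to compound 3 (2.68 log units; beyond the scatter) in this assay, so this position is far from indifferent to the group it carries. Both groups hold one six-membered aromatic ring of carbon only, so the step goes with what surrounds that ring: the smaller phenyl, with no hydrogen-bond acceptors, gives the stronger inhibitor of this pair. Nothing available explains why the number falls so far.

The compounds shown do not separate the part played by the two methoxy groups from that of the oxygen joining the ring to the chain, so plain phenoxy could fall near either compound 2 or compound 3. Going by these compounds, how a longer chain carrying the phenyl would behave also remains open.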